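Taking the triazolylpropyl chain off compound 1

The source may hold more compounds than are shown below. What is called first, only, known or untested is meant among the compounds shown, and "the series" means these compounds.

Measured so far in a functional assay on A549 cells (Homo sapiens) for antiproliferative activity, read by MTT assay, with a stated time of 48 h; a higher number here means a weaker inhibitor, a lower number a stronger inhibitor:
Compound 1 `Cn1cc(C2=C(c3nn(CCCn4cncn4)c4ncccc34)C(=O)NC2=O)c2ccccc21`: > 100000 nM (a limit)
Compound 2 `Cn1cc(C2=C(c3nn(CCn4ccnc4)c4ncccc34)C(=O)N(c3ccccc3)C2=O)c2ccccc21`: 43100 nM
Compound 3 `CN(C)CCCn1nc(C2=C(c3cn(C)c4ccccc34)C(=O)N(c3ccccc3)C2=O)c2cccnc21`: 13000 nM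

Compound 1 gives only a limit and no number. It stands at the limit of > 100000 nM in this assay, at which 1 of the 3 values shown sits.

Compound 4 `Cn1cc(C2=C(c3n[nH]c4ncccc34)C(=O)NC2=O)c2ccccc21` is compound 1 with a single change: hydrogen in place of 3-(1H-1,2,4-triazol-1-yl)propyl on an aromatic nitrogen. The 3-(1H-1,2,4-triazol-1-yl)propyl group leaves, and hydrogen takes its place on the aromatic nitrogen.

For the measured compounds named here, only one measured step bears on this, and only loosely. Swapping the group on the chain gives a 3.3-fold lower number from compound 2 to compound 3 (0.52 log units; beyond the scatter). That step alters a chain rather than removing it, and compounds 2 and 3 also differ from compound 1 elsewhere in the structure. With so little evidence, a modest step toward a lower number is expected in this assay, though another limit remains possible.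

For compound 4 the estimated value is 40000 nM, with an expected range of 10000 nM to 100000 nM. The expected change is an at least 2.5-fold lower number from compound 1 to compound 4 (0.39 log units; beyond the scatter).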

Compound 4, half-maximal inhibitory concentration: > 100000 nM
Compound 4 gave a limit, no number; the forecaster's own chance of this, stated with the estimate: 35%; middle value at least 2.5-fold (0.39 log units) from the limit.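

In this assay compound 1 and compound 4 both give only a limit, not a number, and the step between them cannot be read: the limit of > 100000 nM in this assay, at which 2 of the 4 values shown sit.

The compounds shown leave open whether the 3-(1H-1,2,4-triazol-1-yl)propyl group changes antiproliferative activity on this core at all.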